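This account rests on a few compounds, and the source may have more. Where it says the series, first, only, none or still open, it means among the compounds named here.

Measured so far in an ADME assay on the whole organism (Rattus norvegicus) for pharmacokinetics, read by LC-MS; on this read-out higher numbers stand for fast clearance and lower numbers for slow clearance:

- compound 1 `Cc1ccc(-c2c3c(nc(C)c2C(OC(C)(C)C)C(=O)O)CCN(Cc2ccccc2-c2ccccc2)C3)cc1`: 24 mL/min/kg
- compound 2 `Cc1ccc(-c2c3c(nc(C)c2[C@H](OC(C)(C)C)C(=O)O)CCN(CCCc2ccccc2)C3)cc1`: 171 mL/min/kg
- compound 3 `Cc1nc2c(c(-c3cc(F)c4c(c3C)CCCO4)c1[C@H](OC(C)(C)C)C(=O)O)CN(CCCc1ccc(F)cc1)CC2`: 92 mL/min/kg

Compound 2, at 171 mL/min/kg, belongs to the high-clearance end of this small set. Compound 3, at 92 mL/min/kg, lies within the usual scatter of it, so the two cannot be told apart. Compound 1, at 24 mL/min/kg, lies lower than compound 2 by a margin well beyond the scatter.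

The next compound is compound 4 `Cc1ccc(-c2c3c(nc(C)c2[C@H](OC(C)(C)C)C(=O)O)CCN(Cc2ccccc2)C3)cc1`, not yet measured in this assay. Its difference from compound 2 is phenyl in place of phenethyl on a saturated chain carbon bound to an amine nitrogen in a ring. Cut one bond further out, the same difference reads 3-phenylpropyl to benzyl.

For the measured compounds named here, no pair of measured compounds differs in one place only, so the size of this step has no direct precedent. The expectation rests only on the spread of values, with compound 1 at 24 mL/min/kg showing that much lower clearance occurs in this set. A fall in clearance is expected for a 2.4-fold lower number from compound 2 to compound 4 (0.39 log units; beyond the scatter), of a size only modestly beyond the scatter, and a result within the scatter would be no surprise. For compound 4 the estimated clearance is 70 mL/min/kg, with an expected range of 28 mL/min/kg to 165 mL/min/kg.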

Compound 4, clearance: 21 mL/min/kg
Compound 4: the middle estimate sits 3.3-fold (0.52 log units) above what was measured; measured number outside the range, below it.
By their numbers in this assay, from the lowest: compounds 4 and 1 (each within the scatter of the next); then compounds 3 and 2 (each within the scatter of the next).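

For the compounds shown here, replacing 3-phenylpropyl with benzyl, on a saturated chain carbon bound to an amine nitrogen in a ring, gives an 8.1-fold lower number from compound 2 to compound 4 (0.91 log units; beyond the scatter) in this assay and is the first single-place step. Going by these compounds alone, it shows that this position alone can move clearance by a margin beyond the scatter, with the six-membered aromatic ring of carbon kept and the rest of the structure unchanged, which the earlier compounds, differing in more than one place, could not show. Nothing measured here accounts for the fall in clearance with this change.

This single pair gives two chain lengths only, so it does not establish whether clearance follows chain length in general, or how 2-phenylethyl or a chain longer than 3-phenylpropyl would read in this assay on the same core. Also open, from the compounds shown here alone, are the effect of a nitrile or an amide on the phenyl of benzyl, and whether the same step holds on the core of compound 3.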